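This account rests on a few compounds, and the source may have more. Where it says the series, first, only, none or still open, it means among the compounds named here.

Among the compounds with values here, in a functional assay on DU-145 cells (Homo sapiens) for inhibition, read by MTT assay, with a stated time of 72 h (a higher number here means a weaker inhibitor, a lower number a stronger inhibitor), three compounds sharing one core have numbers so far. Compound 1 `COc1ccc(N2CCN(C3=CC(=O)c4ccccc4C3=O)CC2)cc1` gives 46100 nM, compound 3 `COc1cc(N2CCN(C3=CC(=O)c4ccccc4C3=O)CC2)cc(OC)c1OC` gives 11600 nM, and compound 2 `O=C1C=C(N2CCN(c3ccccc3Cl)CC2)C(=O)c2ccccc21` gives 2900 nM, the lowest of the three. Compound 4 `O=C1C=C(N2CCN(c3ccc(F)c(Cl)c3)CC2)C(=O)c2ccccc21` has not yet been measured. Its difference from compound 2 is 3-chloro-4-fluorophenyl in place of 2-chlorophenyl on an amine nitrogen in a ring. Within the data shown here, only one measured step bears on this place, a 16-fold lower number from compound 1 to compound 2 (1.20 log units; beyond the scatter). That step is large, so the group at this position can clearly move the number, but it starts from a 4-methoxyphenyl group and says little about exchanging one chlorine-bearing group for another. Compound 2 has the lowest number of the set at 2900 nM, so a moderate rise is more likely than a further fall, and a much smaller change than the measured step is expected. The expected step is a 1.7-fold higher number from compound 2 to compound 4 (0.24 log units; within the scatter). For compound 4 the estimated value is 5000 nM, with an expected range from 1700 nM to 15000 nM.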

Compound 4, half-maximal inhibitory concentration: 32200 nM
Compound 4: middle estimate off by 6.4-fold (0.81 log units), on the low side, outside the stated range (above it).
By their numbers in this assay, from the lowest: compound 2; then compound 3; then compounds 4 and 1 (each within the scatter of the next).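

In this assay, the group on the amine nitrogen in a ring can move the number strongly even when a chlorine-bearing group replaces another chlorine-bearing group: the exchange gives an 11-fold higher number from compound 2 to compound 4 (1.05 log units; beyond the scatter). Carrying a chlorine on the phenyl ring is therefore not enough to reach the low number of compound 2. The low number does not carry over to the new group either, as 3-chloro-4-fluorophenyl in place of 4-methoxyphenyl gives only a 1.4-fold lower number from compound 1 to compound 4 (0.16 log units; within the scatter), which leaves compound 4 within the scatter of compound 1.

The compounds shown leave open how an unsubstituted phenyl group or a benzyl group would read at this position. Nothing measured here bears on why the two chlorine-bearing groups differ so widely.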